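Fluoro to methoxy: a change at the assay limit

This account rests on a few compounds, and the source may have more. Where it says the series, first, only, none or still open, it means among the compounds named here.

Compound 1 `O=C(COc1ccc2c(=O)cc(-c3ccccc3)oc2c1)Nc1ccccc1` and compound 2 `O=C(COc1ccc2c(=O)cc(-c3ccccc3)oc2c1)Nc1ccc(F)cc1` share one core and differ only by a fluoro in place of hydrogen on an aromatic carbon. In a functional assay on NPC-TW01 cells (Homo sapiens) for antiproliferative activity, read by MTT assay, with a stated time of 72 h (a lower number here means a stronger inhibitor of growth, a higher number a weaker inhibitor of growth), compound 1 gives > 10000 nM, which is a limit of the assay rather than a number. In this assay compound 2 gives > 10000 nM, again a limit. The step that the two limits leave unreadable from compound 1 to compound 2 cannot be sized because of the limit of > 10000 nM in this assay, at which 2 of the 2 values shown sit. Compound 3 `COc1ccc(NC(=O)COc2ccc3c(=O)cc(-c4ccccc4)oc3c2)cc1` carries methoxy in place of fluoro on an aromatic carbon. For the measured compounds named here, the single measured step offers no readable size, so nothing measured sets a direction for the change from compound 2 to compound 3. Compound 3 is therefore expected to remain near the limit, with an estimated step that the limit leaves unreadable from compound 2 to compound 3. The estimate for compound 3 is 15000 nM, ranging from 4000 nM to 60000 nM, and this assay will most likely again report only a limit.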

Compound 3, concentration for 50% growth inhibition: 5970 nM
Compound 3: the middle estimate sits 2.5-fold (0.40 log units) above what was measured, within the range that was stated.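

With methoxy on this aromatic carbon, para to a large group, the series gives its first actual number in this assay, where hydrogen and fluoro gave only limits. Methoxy in place of fluoro gives an at least 1.6-fold lower number from compound 2 to compound 3 (0.22 log units; that floor lies within the scatter), and methoxy in place of hydrogen gives an at least 1.6-fold lower number from compound 1 to compound 3 (0.22 log units; that floor lies within the scatter). Each of these is only a floor, and the full size of neither step can be read because compound 1 and compound 2 give no number: the limit of > 10000 nM in this assay, at which 2 of the 3 values shown sit.

The compounds shown leave open whether the real gaps reach beyond the usual scatter. They also leave open whether another group on this carbon, such as an amine, a carboxylic acid or a longer chain like ethoxy, would give a lower number than methoxy, a similar one or only a limit.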